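This account rests on a few compounds, and the source may have more. Where it says the series, first, only, none or still open, it means among the compounds named here.

The measured compounds, all in a functional assay on PC-3 cells (Homo sapiens) for inhibition, read by sulforhodamine B assay; a higher number here means a weaker inhibitor of growth, a lower number a stronger inhibitor of growth:

compound 1 `O=C(CCC1=CCN(CCCc2ccc(Cl)cc2)C1=O)NO` gives 3480 nM
compound 2 `CC(C)(C)c1ccc(CCCN2CC=C(CCC(=O)NO)C2=O)cc1` gives 3480 nM
compound 3 `O=C(CCC1=CCN(Cc2ccc(Cl)cc2)C1=O)NO` gives 4620 nM

Compound 1 and compound 2 share a core and differ in one place, (tert-butyl in place of chloro on an aromatic carbon). Going by the values given here, the step of no change at the digits printed from compound 1 to compound 2 (within the scatter) is the only measured instance of this change, and it stays within the scatter. Compound 3 carries a different core, and the difference between the two cores is not broken down here; its value and that of compound 1 lie within the scatter of each other, so the two values show no separation.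

Compound 4 `CC(C)(C)c1ccc(CN2CC=C(CCC(=O)NO)C2=O)cc1` is the unmeasured compound. It stands to compound 3 as compound 2 stands to compound 1: tert-butyl in place of chloro on an aromatic carbon. The place is described in the same words for both pairs, so it is the same change. On the basis of compound 1 and compound 2, whose step was no change at the digits printed from compound 1 to compound 2 (within the scatter), the step for compound 4 is expected to be a 1.0-fold lower number from compound 3 to compound 4 (0.00 log units; within the scatter), a flat step. Compound 4 is therefore expected to give 4600 nM in this assay, most likely between 2300 nM and 9200 nM.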

Compound 4, concentration for 50% growth inhibition: 1830 nM
Estimate against measurement, compound 4: 2.5-fold (0.40 log units) above; the measured number lies below the stated range.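

In this assay, tert-butyl in place of chloro on an aromatic carbon gives a 2.5-fold lower number from compound 3 to compound 4 (0.40 log units; beyond the scatter), a modest step on the core of compound 3. Set beside the same change on the core of compound 1, the two steps do not separate: the same change on two cores in this assay, no change at the digits printed (within the scatter) from compound 1 to compound 2 and a 2.5-fold lower number (0.40 log units; beyond the scatter) from compound 3 to compound 4, 2.5-fold (0.40 log units) apart, within the scatter of two such steps. Going by these compounds alone, this shows that the result on one core is compatible with the result on the other, but it does not show that the change acts alike on both, as the comparison rests on a single pair of compounds for each core and only one of the two steps lies beyond the scatter.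

The compounds shown leave open how other groups at this place, such as methoxy, trifluoromethyl or an amine, would compare with chloro and tert-butyl, and whether the step would hold on a core with a longer chain than that of compound 1. They also leave open whether it would survive replacing the hydroxamic acid with a carboxylic acid.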